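The source may hold more compounds than are shown below. What is called first, only, known or untested is meant among the compounds shown, and "the series" means these compounds.

In an ADME assay on WI-38 cells (Homo sapiens) for cytotoxicity, read by MTT assay, with a stated time of 72 h (on this read-out higher numbers stand for weaker inhibition and lower numbers for stronger inhibition), compound 1 `O=C(CCc1cccc2c1B(O)OC2)Nc1ccccc1` gives 30000 nM and compound 2 `O=C(CCc1cccc2c1B(O)OC2)Nc1ccc(F)cc1` gives 12000 nM. Compound 3 `C#Cc1ccc(NC(=O)CCc2cccc3c2B(O)OC3)cc1` gives > 100000 nM, which is a limit of the assay and not a number. Compound 3 thus stands at the limit of > 100000 nM in this assay, at which 1 of the 3 values shown sits.

Compound 4 `CC(C)(C)OC(=O)NCc1ccc(NC(=O)CCc2cccc3c2B(O)OC3)cc1` carries ((tert-butoxycarbonyl)amino)methyl in place of ethynyl on an aromatic carbon, para to a large group (((tert-butoxycarbonyl)amino)methyl in place of ethynyl on an aromatic carbon). Two steps give the scale: a 2.5-fold lower number from compound 1 to compound 2 (0.40 log units; beyond the scatter) and an at least 8.3-fold higher number from compound 2 to compound 3 (0.92 log units; beyond the scatter). With ethynyl leaving, a modest move to a lower number is expected in this assay, the reverse of an at least 3.3-fold higher number from compound 1 to compound 3 (0.52 log units; beyond the scatter). The expected step is an at least 2.8-fold lower number from compound 3 to compound 4 (0.45 log units; beyond the scatter). For compound 4 the estimate is 35000 nM, with an expected range of 12000 nM to 90000 nM.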

Compound 4, half-maximal inhibitory concentration: 4800 nM
For compound 4 the middle estimate is 7.3-fold (0.86 log units) above the measured one; measured number below the stated range.
By their numbers in this assay, from the lowest: compound 4; then compound 2; then compound 1. At a limit, above all of these: compound 3.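

In this assay the lowest number at this position comes with its largest group, ((tert-butoxycarbonyl)amino)methyl: a 6.3-fold lower number from compound 1 to compound 4 (0.80 log units; beyond the scatter) and a 2.5-fold lower number from compound 2 to compound 4 (0.40 log units; beyond the scatter). Group size alone does not order the series, as ethynyl in compound 3 goes against that reading, with an at least 20-fold lower number from compound 3 to compound 4 (1.31 log units; beyond the scatter). The value of compound 3 is a limit and not a number: the limit of > 100000 nM in this assay, at which 1 of the 4 values shown sits.

The compounds shown leave open whether the lower number of compound 4 follows the whole group or only a part of it. A free aminomethyl or a carboxylic acid in this place would bear on that question.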